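Butyl(ethyl)amino replacing the dimethoxy side chain

The compounds below may be only part of what the source reports. "The series", "measured", "known", "first", "only" and "open" are said of these compounds alone.

Compound 2 `COCC(COC)N(C)c1nc(C)nc2c1nnn2-c1ccc(C(C)C)cc1Br` stands highest of the two numbers in an in vitro assay on 293-EBNA cells for binding affinity to corticotropin-releasing factor receptor 1 (Homo sapiens) (a higher number here means a weaker inhibitor, a lower number a stronger inhibitor), where compound 2 gives 21.3 nM; compound 1 `COCC(COC)Nc1nc(C)nc2c1nnn2-c1ccc(C(C)C)cc1Br` gives 10.3 nM. Going by the values given here, the single measured step, a 2.1-fold higher number from compound 1 to compound 2 (0.32 log units; beyond the scatter), is the only guide. Compound 3 `CCCCN(CC)c1nc(C)nc2c1nnn2-c1ccc(C(C)C)cc1Br` differs from compound 2 by a group of 7 heavy atoms (6 carbon, 1 nitrogen; no ring) in place of a group of 9 heavy atoms (6 carbon, 1 nitrogen, 2 oxygen; no ring), on an aromatic carbon. Among the compounds with values here, no measured step covers such an exchange; the methylation step only shows that altering the amino substituent shifts this assay modestly. The expected step of a 1.4-fold lower number from compound 2 to compound 3 (0.15 log units; within the scatter) is therefore small, with wide uncertainty. Compound 3 is estimated at 15 nM, range 4 nM to 60 nM.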

Compound 3, inhibition constant: 7.5 nM
For compound 3 the middle estimate is 2.0-fold (0.30 log units) above the measured one; measured number inside the range.
By their numbers in this assay, from the lowest: compounds 3 and 1 (each within the scatter of the next); then compound 2.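

In this assay, butyl(ethyl)amino on this aromatic carbon gives a 2.8-fold lower number from compound 2 to compound 3 (0.45 log units; beyond the scatter) and shows that the position accepts a side chain with no oxygen. Set against (2-methoxy-1-(methoxymethyl)ethyl)amino, the same group gives a 1.4-fold lower number from compound 1 to compound 3 (0.14 log units; within the scatter) and so leaves the two side chains unseparated here, which means the oxygen atoms of the dimethoxy chain are not required for a number in this range. No evidence on the reason for either step is available. Open, from the compounds shown here alone, is how a shorter dialkylamino group such as diethylamino, or a longer chain such as dibutylamino, would read at this position. Going by these compounds, a ring amine such as morpholine also remains open.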